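Working notes: five-membered ring variation in this series

The compounds below may be only part of what the source reports. "The series", "measured", "known", "first", "only" and "open" are said of these compounds alone.

Values in an assay for activation of Adrenergic receptor alpha-1 (Rattus norvegicus); a higher number here means that more compound is needed for the effect, a lower number that less compound is needed:
compound 1 `c1ccc2c(c1)CC2CCCN1CCN(c2cccc3c2OCCO3)CC1`: 0.45 mg/kg
compound 2 `c1ccc2c(c1)CCC2CCN1CCN(c2cccc3c2OCCO3)CC1`: 4.01 mg/kg
compound 3 `c1ccc2c(c1)CC(CCN1CCN(c3cccc4c3OCCO4)CC1)C2`: 0.66 mg/kg

Compound 3 stands second highest of the three numbers. Its nearest neighbour is compound 1, and the step of a 1.5-fold higher number from compound 1 to compound 3 (0.17 log units; within the scatter) is within the scatter, so no order between these two is claimed. Its furthest neighbour is compound 2, and the step of a 6.1-fold lower number from compound 2 to compound 3 (0.78 log units; beyond the scatter) is beyond the scatter.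

Compound 4 `C1=C(CCN2CCN(c3cccc4c3OCCO4)CC2)c2ccccc2C1` is not yet measured. Against compound 3 the change is a group of 9 heavy atoms (9 carbon; one five-membered non-aromatic ring of carbon only, one six-membered aromatic ring of carbon only) in place of a group of 9 heavy atoms (9 carbon; one five-membered non-aromatic ring of carbon only, one six-membered aromatic ring of carbon only), on a saturated chain carbon, two bonds along the chain from an amine nitrogen in a ring. For the measured compounds named here, no measured step exchanges a saturated five-membered ring for one carrying a double bond outside aromatic rings, so nothing bears on it directly. What the measured steps show is the range this group can cover: an 8.9-fold higher number from compound 1 to compound 2 (0.95 log units; beyond the scatter) and a 6.1-fold lower number from compound 2 to compound 3 (0.78 log units; beyond the scatter) are both modest and beyond the scatter, while a 1.5-fold higher number from compound 1 to compound 3 (0.17 log units; within the scatter) is within it. A change at this place can therefore move the number modestly in either direction or not at all.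

For compound 4 the expectation is a number near that of compound 3, estimated at 1 mg/kg with a range from 0.3 mg/kg to 4 mg/kg. The expected step is a 1.5-fold higher number from compound 3 to compound 4 (0.18 log units; within the scatter), with the direction left open.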

Compound 4, dose for half-maximal effect: 0.3 mg/kg
Compound 4: the middle estimate sits 3.3-fold (0.52 log units) above what was measured; the range from low to high includes it.
By their numbers in this assay, from the lowest: compounds 4, 1 and 3 (each within the scatter of the next, the first and the last beyond it); then compound 2.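

In this assay, for the compounds shown here, the entering group, with its one double bond outside aromatic rings, gives the first large step at this place: a 13-fold lower number from compound 2 to compound 4 (1.13 log units; beyond the scatter). The high number of compound 2 is therefore not shared by every group of this size with a five-membered non-aromatic ring, and compound 2 now stands apart from all three other compounds. Against 2,3-dihydro-1H-inden-2-yl the step of a 2.2-fold lower number from compound 3 to compound 4 (0.34 log units; beyond the scatter) is modest but beyond the scatter, while a 1.5-fold lower number from compound 1 to compound 4 (0.18 log units; within the scatter) lies within it, so no order is claimed between these two, and no measurement offered here accounts for any of these steps.

The compounds shown do not separate the contribution of the double bond from that of the point at which the ring system joins the chain, since compound 3 and compound 4 differ in both. Also open, going by these compounds, is whether the low numbers persist with a longer chain on the group of compound 4, with a methyl group on its double bond, or with a six-membered non-aromatic ring of carbon only in place of the five-membered one.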